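A few compounds are considered here, and "the series" means these few. Any claim that something is new, unique, unknown or untested is made for them only; others in the source may bear on it.

Measured compounds in this series:

Compound 1 `O=C(NCc1ccc(S(=O)(=O)c2ccccc2)cc1)NCc1cccnc1` gives 19 nM in an assay on isolated protein for inhibition of Nicotinamide phosphoribosyltransferase (Homo sapiens), read by mass spectrometry, with stated times of 15 min and 30 min; a higher number here means a weaker inhibitor, a lower number a stronger inhibitor.
Compound 2 `CCCn1cc(S(=O)(=O)c2ccc(CNC(=O)N3Cc4ccncc4C3)cc2)cn1` gives 17 nM in this assay.
Compound 3 `O=C(NCc1ccc(S(=O)(=O)C2CCN(C3COC3)CC2)cc1)N1Cc2ccncc2C1` gives 31 nM in this assay.

Compound 2 holds the lowest of the three numbers, though neither neighbour is separated from it beyond the scatter: compound 1 sits nearest and compound 3 furthest, both within the usual spread of repeats. The unmeasured compound 4 `CN1CCC(S(=O)(=O)c2ccc(CNC(=O)N3Cc4ccncc4C3)cc2)CC1` keeps the shared core of compound 2 and alters only the substituent on the sulfonyl sulfur: 1-methylpiperidin-4-yl in place of 1-propyl-1H-pyrazol-4-yl on a sulfonyl sulfur. Among the compounds with values here, the one measured step that bears on this is a 1.8-fold higher number from compound 2 to compound 3 (0.26 log units; within the scatter), in which the same 1-propyl-1H-pyrazol-4-yl on the sulfonyl sulfur was replaced by a piperidin-4-yl carrying an oxetan-3-yl on its nitrogen; that change stayed within the scatter. Compound 4 carries a methyl on the piperidine nitrogen instead, a smaller variation on the same theme. Within the data shown here, no measured step isolates the effect of the group on that nitrogen, so nothing beyond a small shift in this assay, if any, is expected; the step of a 1.5-fold higher number from compound 2 to compound 4 (0.17 log units; within the scatter) is estimated to lie within the scatter, leaning, if at all, toward a slightly higher number as seen for compound 3. Compound 4 is therefore expected to give about 25 nM, with a plausible range of 12 nM to 55 nM.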

Compound 4, half-maximal inhibitory concentration: 48 nM
The estimate for compound 4 lay 1.9-fold (0.28 log units) below the measured number, within the range that was stated.
By their numbers in this assay, from the lowest: compounds 2, 1, 3 and 4 (each within the scatter of the next, the first and the last beyond it).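

Within the data shown here, on the sulfonyl sulfur, 1-methylpiperidin-4-yl in place of 1-propyl-1H-pyrazol-4-yl gives a 2.8-fold higher number from compound 2 to compound 4 (0.45 log units; beyond the scatter) in this assay and is the first change at this position to pass beyond the scatter, though only modestly, while the replacement carrying an oxetan-3-yl on the piperidine nitrogen stays inside it with a 1.8-fold higher number from compound 2 to compound 3 (0.26 log units; within the scatter) as its step. Among these compounds, the pair also gives the first direct reading of the group on that ring nitrogen: methyl in place of oxetan-3-yl gives a 1.5-fold higher number from compound 3 to compound 4 (0.19 log units; within the scatter) and so does not separate the two groups. No measurement at hand accounts for the step away from the pyrazole.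

The compounds shown leave open how a piperidin-4-yl with a free amine hydrogen, or with an ethyl or acetyl group on its nitrogen, would compare with the methyl and oxetan-3-yl groups. They also leave open whether a 1-methyl-1H-pyrazol-4-yl on the sulfonyl sulfur would stay level with the 1-propyl-1H-pyrazol-4-yl group, a comparison that would show how much of the step depends on the propyl chain rather than on the ring.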